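Piperidinyl to diethylamino on the cytotoxicity of three isatin-derived compounds

The compounds below may be only part of what the source reports. "The series", "measured", "known", "first", "only" and "open" are said of these compounds alone.

Compound 1 `CCN(CC)CN1C(=O)/C(=N\c2nc3ccc(C)cc3s2)c2ccccc21` in an ADME assay on MCF-10A cells (Homo sapiens) for cytotoxicity, read by sulforhodamine B assay, with a stated time of 48 h (on this read-out higher numbers stand for weaker inhibition of growth and lower numbers for stronger inhibition of growth), gives 20400 nM.
Compound 2 `Cc1ccc2nc(/N=C3\C(=O)N(CN4CCCCC4)c4ccccc43)sc2c1` in this assay gives 38900 nM.
Compound 3 `O=C1C(=O)N(CN2CCCCC2)c2cccc(Cl)c21` in this assay gives 70700 nM.

Compound 1 and compound 2 share one core and differ only at the chain on the ring nitrogen: diethylamino in place of piperidin-1-yl on a saturated chain carbon bound to an amide-type nitrogen in a ring. The measured step in this assay is a 1.9-fold lower number from compound 2 to compound 1 (0.28 log units; within the scatter), which lies within the usual scatter, so the two values are treated as alike.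

Compound 3 carries a different core; how its core differs from that of compound 2 is not broken down here. Its value in this assay stands closest to that of compound 2, within the scatter, and farthest from that of compound 1, beyond the scatter.

Compound 4 `CCN(CC)CN1C(=O)C(=O)c2c(Cl)cccc21` has not yet been measured. It differs from compound 3 by diethylamino in place of piperidin-1-yl on a saturated chain carbon bound to an amide-type nitrogen in a ring, the same change that turns compound 2 into compound 1, at the same place. The expectation for compound 4 therefore rests on that one precedent, on a different core, and on nothing else.

In this assay the estimated step is a 1.8-fold lower number from compound 3 to compound 4 (0.25 log units; within the scatter), because the same change gave a 1.9-fold lower number from compound 2 to compound 1 (0.28 log units; within the scatter) and that step stayed within the scatter. Compound 4 is thus expected near 40000 nM, with four of five such measurements expected between 18000 nM and 90000 nM.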

Compound 4, concentration for 50% growth inhibition: 35000 nM
For compound 4 the middle estimate is 1.1-fold (0.06 log units) above the measured one; measured number inside the range.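

In this assay, diethylamino in place of piperidin-1-yl on a saturated chain carbon bound to an amide-type nitrogen in a ring now gives a 2.0-fold lower number from compound 3 to compound 4 (0.31 log units; beyond the scatter). Set beside the earlier case, the change reads as about the same size on the two cores: the same change on two cores in this assay, a 1.9-fold lower number (0.28 log units; within the scatter) from compound 2 to compound 1 and a 2.0-fold lower number (0.31 log units; beyond the scatter) from compound 3 to compound 4, 1.1-fold (0.03 log units) apart, within the scatter of two such steps. This supports carrying the change from one of these cores to the other as a modest step, but it rests on one pair per core, with one step inside the scatter and the other only just beyond it, so it does not establish a firm gain from the change, does not show that the step would hold on any further core, and gives no reason for the step.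

The compounds shown leave open whether another amine on the same chain carbon, such as morpholine or dimethylamino, would give a step of like size, and whether a longer chain between the amine and the ring nitrogen would alter it. They also leave open whether the same exchange would show a like step on any read-out other than this assay.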